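Swapping isopropyl for cyclopropyl on compound 3

The source may hold more compounds than are shown below. What is called first, only, known or untested is meant among the compounds shown, and "the series" means these compounds.

Compound 1 `COc1cc(-c2nnc3c(OC(C)C)cc(-c4ccc5[nH]ccc5c4)cn23)cc(OC)c1OC` gives 1020 nM
Compound 2 `COc1cc(-c2nnc3c(OC4CC4)cc(-c4ccc5[nH]ccc5c4)cn23)cc(OC)c1OC` gives 259 nM
Compound 3 `COc1cc(-c2nnc3c(OC(C)C)cc(-c4ccc5c(ccn5C)c4)cn23)cc(OC)c1OC` gives 204 nM

All three numbers come from a functional assay on MCF7 cells (Homo sapiens) for antiproliferative activity, read by MTT assay, with a stated time of 48 h (a higher number here means a weaker inhibitor, a lower number a stronger inhibitor), and share one core. Compound 3 differs from compound 1 by a methyl in place of hydrogen on an aromatic nitrogen, which gives a 5.0-fold lower number from compound 1 to compound 3 (0.70 log units; beyond the scatter) in this measure. The values of compound 3 and compound 2 lie within the scatter of each other, so these two cannot be told apart.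

The next compound is compound 4 `COc1cc(-c2nnc3c(OC4CC4)cc(-c4ccc5c(ccn5C)c4)cn23)cc(OC)c1OC` and it keeps that methyl. Its difference from compound 3 is cyclopropyl in place of isopropyl on an oxygen on an aromatic ring and so it has cyclopropyl in place of isopropyl on an oxygen on an aromatic ring.

The same swap has been measured once, without the methyl, as a 3.9-fold lower number from compound 1 to compound 2 (0.60 log units; beyond the scatter) in this measure. Among the measured compounds shown here, no measured compound carries both changes, so whether their effects add up is unknown. A lower number is still expected, though perhaps a smaller drop than that single example. The estimate is a 2.9-fold lower number from compound 3 to compound 4 (0.46 log units; beyond the scatter) in this assay overall.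

Compound 4 is expected at about 70 nM with a likely range of 25 nM to 200 nM in this assay overall.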

Compound 4, half-maximal inhibitory concentration: 118 nM
Compound 4: middle estimate off by 1.7-fold (0.23 log units), on the low side; the measured number falls inside the stated range.
By their numbers in this assay, from the lowest: compounds 4, 3 and 2 (each within the scatter of the next, the first and the last beyond it); then compound 1.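

In this assay, the swap from isopropyl to cyclopropyl on the oxygen now has a second reading, on the core that carries the methyl, and there it reads a 1.7-fold lower number from compound 3 to compound 4 (0.24 log units; within the scatter), so on this core the swap alone cannot be told apart from ordinary scatter. The methyl on the aromatic nitrogen, now also seen with cyclopropyl on the oxygen, reads a 2.2-fold lower number from compound 2 to compound 4 (0.34 log units; beyond the scatter), which stays beyond the scatter, and its size does not differ measurably between the two cores: the same change on two cores in this assay, a 5.0-fold lower number (0.70 log units; beyond the scatter) from compound 1 to compound 3 and a 2.2-fold lower number (0.34 log units; beyond the scatter) from compound 2 to compound 4, 2.3-fold (0.36 log units) apart, within the scatter of two such steps. The cyclopropyl swap also does not differ measurably between its two cores, so these four compounds do not show that the two changes interfere with each other, nor do they prove that the changes simply add: the same change on two cores in this assay, a 3.9-fold lower number (0.60 log units; beyond the scatter) from compound 1 to compound 2 and a 1.7-fold lower number (0.24 log units; within the scatter) from compound 3 to compound 4, 2.3-fold (0.36 log units) apart, within the scatter of two such steps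

The compounds shown hold only isopropyl or cyclopropyl on this oxygen and only hydrogen or methyl on the aromatic nitrogen. As far as these compounds go, whether a cyclobutyl or a chain ending in an amine on the oxygen, or an ethyl on the nitrogen, would move the number further remains open.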